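Aryl variation at the shared core, compound 3

The source may report more compounds than this note shows. Statements on the series, on what has been measured and on what is new or still open speak of the compounds shown alone.

In an in vitro functional assay on HEK285-7 cells for antagonist activity at prostaglandin D2 receptor 2 (Homo sapiens), read by BRET and beta-arrestin recruitment (on this read-out higher numbers stand for weaker inhibition and lower numbers for stronger inhibition), compound 1 `CS(=O)(=O)Nc1cccc(-c2nc(C(c3ccc(F)cc3)c3ccc(F)cc3)sc2CC(=O)O)c1` gives 370 nM and compound 2 `O=C(O)Cc1sc(C(c2ccc(F)cc2)c2ccc(F)cc2)nc1-c1ccnc(O)c1` gives 890 nM, the highest of the two numbers, with compound 1 the nearest. Going by the values given here, the only measured step at this position is a 2.4-fold higher number from compound 1 to compound 2 (0.38 log units; beyond the scatter). Compound 3 `Cc1cc(-c2nc(C(c3ccc(F)cc3)c3ccc(F)cc3)sc2CC(=O)O)cnc1N` carries the change (6-amino-5-methylpyridin-3-yl in place of 2-hydroxypyridin-4-yl on an aromatic carbon). That one step was modest and swapped a different pair of groups, so it sets only the scale of what an aryl swap here can do, not its direction. The number for compound 3 is therefore expected to move little, a 1.3-fold lower number from compound 2 to compound 3 (0.10 log units; within the scatter), estimated at 700 nM within 300 nM to 1600 nM.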

Compound 3, half-maximal inhibitory concentration: > 100000 nM
Compound 3: a limit, no number; the forecaster's own chance of this, stated with the estimate: 5%; middle value at least 140-fold (2.15 log units) away from the limit.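

Compound 3 stands as a limit of the assay, not as a number: the limit of > 100000 nM in this assay, at which 1 of the 3 values shown sits. At this aromatic carbon next to the ring nitrogen, an aryl swap need not be modest: 6-amino-5-methylpyridin-3-yl gives an at least 110-fold higher number from compound 2 to compound 3 (2.05 log units; beyond the scatter) and an at least 270-fold higher number from compound 1 to compound 3 (2.43 log units; beyond the scatter), whereas the earlier pair showed only a 2.4-fold higher number from compound 1 to compound 2 (0.38 log units; beyond the scatter).

Going by these compounds, the true size of both new steps remains open, as does which part of the entering group goes with the change. A 6-aminopyridin-3-yl group without the methyl, or a 5-methylpyridin-3-yl group without the amine, would separate the two.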